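Amide substituent swap on the compound 3 scaffold

A few compounds are considered here, and "the series" means these few. Any claim that something is new, unique, unknown or untested is made for them only; others in the source may bear on it.

Compound 1 `CN1CCCC(NS(=O)(=O)c2ccccc2Nc2cc(-c3ccc4ccn(C)c4c3)c3nccnc3c2)C1` and compound 2 `CN(Cc1cncnc1)S(=O)(=O)c1ccccc1Nc1cc(-c2ccc3ccn(C)c3c2)c2nccnc2c1` carry a sulfonamide attachment, while compound 3 `CC(=O)N1CCC(NC(=O)c2ccncc2Nc2cc(-c3ccc4ccn(C)c4c3)c3nccnc3c2)CC1` carries an amide. In an assay for inhibition of 6-phosphofructo-2-kinase/fructose-2,6-bisphosphatase 3 (Homo sapiens), read by ADP-Glo, with a stated time of 2 h (a lower number here means a stronger inhibitor, a higher number a weaker inhibitor), compound 1 gives 59 nM and compound 2 gives 62 nM, whereas compound 3 gives 18 nM, the lowest of the three numbers. Compound 4 `CN1CCC(CNC(=O)c2ccncc2Nc2cc(-c3ccc4ccn(C)c4c3)c3nccnc3c2)C1` is not yet measured; it differs from compound 3 by (1-methylpyrrolidin-3-yl)methyl in place of 1-acetylpiperidin-4-yl on an amide-type nitrogen. For the measured compounds named here, the only measured step, a 1.1-fold higher number from compound 1 to compound 2 (0.02 log units; within the scatter), exchanges the group on the sulfonyl sulfur rather than on the amide nitrogen, so it bears on this change only loosely, though it shows such an exchange leaving the number within the scatter. Going by the values given here, no measured step alters the amide substituent itself. The step of a 1.4-fold higher number from compound 3 to compound 4 (0.14 log units; within the scatter) is therefore expected to stay within the scatter, with no settled direction. Compound 4 is estimated at 25 nM, ranging from 8 nM to 80 nM.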

Compound 4, half-maximal inhibitory concentration: 74 nM
Beside the measured number, compound 4's estimate is 3.0-fold (0.47 log units) below it, within the range that was stated.
By their numbers in this assay, from the lowest: compound 3; then compounds 1, 2 and 4 (each within the scatter of the next).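

On the amide-type nitrogen, the substituent exchange moves the number in this assay beyond the scatter, a 4.1-fold higher number from compound 3 to compound 4 (0.61 log units; beyond the scatter), so this position responds in a way the sulfonyl-sulfur exchange, a 1.1-fold higher number from compound 1 to compound 2 (0.02 log units; within the scatter), did not show. The change alters ring size, the acetyl group and the methyl spacer at once, and these cannot be separated here. Nothing available explains the shift.

Open, as far as these compounds go, is which of these parts carries the step. A 1-methylpiperidin-4-yl group on the same nitrogen would separate the acetyl group from the ring size.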